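One Amide Substituent, Two Measurements, a Third Expected

The source may report more compounds than this note shows. Statements on the series, on what has been measured and on what is new or still open speak of the compounds shown alone.

Compound 1 `CN(C)C(=O)c1cc2cnc(Nc3ccc(NC(=O)C4(C(=O)Nc5ccc(Cl)c(C(F)(F)F)c5)CC4)cc3)nc2n1C1CCCC1`: 1.1%
Compound 2 `Cc1ccc(NC(=O)C2(C(=O)Nc3ccc(Nc4ncc5cc(C(=O)N(C)C)n(C6CCCC6)c5n4)cc3)CC2)cc1`: 40.2%

Both numbers come from a functional assay on A549 cells (Homo sapiens) for inhibition, read by CCK-8 assay, with a stated time of 72 h, tested at 1 uM; a higher number here means more inhibition of growth at the concentration tested, a lower number less inhibition of growth. Compound 2 stands higher of the two, and the gap to compound 1 lies beyond the usual scatter. The next compound, compound 3 `CN(C)C(=O)c1cc2cnc(Nc3ccc(NC(=O)C4(C(=O)Nc5cccc(C(F)(F)F)c5)CC4)cc3)nc2n1C1CCCC1`, differs from compound 2 at one place, on an amide-type nitrogen: 3-(trifluoromethyl)phenyl in place of 4-methylphenyl on an amide-type nitrogen. In plain words, 3-(trifluoromethyl)phenyl takes the place of 4-methylphenyl.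

Within the data shown here, only one measured step bears on this change. It is a number 39.1 percentage points higher from compound 1 to compound 2 (beyond the scatter), a large step made when 4-methylphenyl replaced 4-chloro-3-(trifluoromethyl)phenyl at the same place. The group entering compound 3 carries the trifluoromethyl of compound 1 but not its chloro, so it resembles the group of the weaker compound. A single step is thin evidence, and it cannot show which part of that group matters. A fall is therefore expected, probably smaller than the full measured gap. The estimate is a number 25.2 percentage points lower from compound 2 to compound 3 (beyond the scatter). For compound 3 the expected value is 15%, with an estimated range from 0% to 38%.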

Compound 3, percent growth inhibition at one concentration: 15.7%
For compound 3 the middle estimate is 0.7 percentage points below the measured one; measured number inside the range.
By their numbers in this assay, from the lowest: compound 1; then compound 3; then compound 2.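

Compound 3 separates the two parts of the group on compound 1, and both turn out to matter at this amide nitrogen. Removing only the chloro, with the trifluoromethyl kept in place, gives a number 14.6 percentage points higher from compound 1 to compound 3 (beyond the scatter) in this assay and so recovers part of the earlier gap, while the exchange of 4-methylphenyl for 3-(trifluoromethyl)phenyl gives a number 24.5 percentage points lower from compound 2 to compound 3 (beyond the scatter) and accounts for the rest. Among these three compounds, growth inhibition therefore depends on what the aromatic ring at this nitrogen carries, and neither the chloro nor the remaining difference explains the whole gap alone; nothing measured here explains why these groups differ.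

Compound 2 and compound 3 differ both in the kind of substituent and in where it sits on the ring, so a plain phenyl, 3-methylphenyl or 4-(trifluoromethyl)phenyl would be needed to tell those two effects apart. Also open, as far as these compounds go, is how these compounds would rank at other concentrations or on other cells, as this assay reports a single concentration on one cell type.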